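The source may hold more compounds than are shown below. What is called first, only, known or untested is meant among the compounds shown, and "the series" means these compounds.

Measured compounds in an assay for inhibition of Fatty-acid amide hydrolase 1 (Rattus norvegicus); on this read-out lower numbers stand for stronger inhibition and higher numbers for weaker inhibition:
compound 1, `O=C(CCc1ccc(-c2ccccc2)cc1)c1ncc(-c2ccncc2)o1` — 2.3 nM
compound 2, `COC(=O)c1cc(-c2cnc(C(=O)CCc3ccc(-c4ccccc4)cc3)o2)ccn1` — 1.5 nM
compound 3, `CN(C)C(=O)c1cnc(C(=O)CCc2ccc(-c3ccccc3)cc2)o1` — 3 nM

Compound 3 gives the highest of the three numbers in this assay, but its distance to the other two is small: a 1.3-fold higher number from compound 1 to compound 3 (0.12 log units; within the scatter) and a 2.0-fold higher number from compound 2 to compound 3 (0.30 log units; within the scatter). All three compounds thus sit together within the usual spread of repeated measurements, and none of them can be set apart from the rest on these numbers.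

Compound 4, `O=C(CCc1ccc(-c2ccccc2)cc1)c1ncc(C(=O)C(F)(F)F)o1`, differs from compound 3 in one place: trifluoromethyl in place of dimethylamino on a carbonyl carbon. For the measured compounds named here, no measured pair shows this exchange. The two steps that touch the same position, a 1.3-fold higher number from compound 1 to compound 3 (0.12 log units; within the scatter) and a 2.0-fold higher number from compound 2 to compound 3 (0.30 log units; within the scatter), brought the dimethylcarbamoyl group in place of an aromatic substituent and changed the read-out little; they show that this position has so far accepted different groups, but they say nothing about the (trifluoromethyl)carbonyl group itself. Going by the values given here, with no step bearing directly on the change, the expected step in this assay is a 1.3-fold higher number from compound 3 to compound 4 (0.12 log units; within the scatter), with the range kept wide enough to allow a shift in either direction. Compound 4 is therefore expected to give about 4 nM, within a range from 0.8 nM to 25 nM.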

Compound 4, inhibition constant: 8 nM
Compound 4: middle estimate off by 2.0-fold (0.30 log units), on the low side, and the stated range covers the measured number.
By their numbers in this assay, from the lowest: compounds 2, 1 and 3 (each within the scatter of the next); then compound 4.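

For the compounds shown here, on this assay, trifluoromethyl in place of dimethylamino on a carbonyl carbon gives a 2.7-fold higher number from compound 3 to compound 4 (0.43 log units; beyond the scatter), the first step at this position to lie beyond the scatter. Set against the aromatic substituents, the (trifluoromethyl)carbonyl group gives a 3.5-fold higher number from compound 1 to compound 4 (0.54 log units; beyond the scatter) and a 5.3-fold higher number from compound 2 to compound 4 (0.73 log units; beyond the scatter), so a position that held pyridin-4-yl, 2-(methoxycarbonyl)pyridin-4-yl and dimethylcarbamoyl with no separable difference does respond to the group placed there, although all three new steps remain modest. No evidence at hand bears on why the number rises with this group.

The compounds shown leave open whether the step belongs to the trifluoromethyl group or to the carbonyl that carries it, a question that a methyl ketone or a carboxylic acid in the same place would help to settle. Also open, going by these compounds, is how far the dimethylamino result extends to other amides, such as a primary amide or a pyrrolidine amide, and whether a longer perfluoroalkyl chain would move the number further in the same direction.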